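This account rests on a few compounds, and the source may have more. Where it says the series, first, only, none or still open, it means among the compounds named here.

Measured compounds:
compound 1, `O=C(Nc1ccc(Cl)cc1)C1CCCN(C(=O)c2cccc(-c3nccs3)c2)C1`, 32%
compound 2, `CSc1cccc(NC(=O)C2CCCN(C(=O)c3cc(C(F)(F)F)cc(C(F)(F)F)c3)C2)c1`, 0%
compound 3, `O=C(Nc1cccc(Oc2ccccc2)c1)C1CCCN(C(=O)c2cc(C(F)(F)F)cc(C(F)(F)F)c2)C1`, 1%

The three measured compounds share a core and were tested in an ADME assay on PC-3 cells (Homo sapiens) for cytotoxicity, read by WST assay, tested at 100 uM; a higher number here means more inhibition at the concentration tested (going by the name of the read-out), a lower number less inhibition. Compound 1 gives 32%, the highest of the three numbers; its nearest neighbour is compound 3 and its furthest is compound 2, both of them lying beyond the scatter below it. For the measured compounds named here, the only step between measured compounds that differ in one place, from compound 2 to compound 3, is a number 1 percentage points higher from compound 2 to compound 3 (within the scatter); it concerns a change on the anilide side and does not touch the group that is exchanged here.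

Compound 4, `CSc1cccc(C(=O)N2CCCC(C(=O)Nc3ccc(Cl)cc3)C2)c1`, is not yet measured. It differs from compound 1 by methylsulfanyl in place of 1,3-thiazol-2-yl on an aromatic carbon. Going by the values given here, no measured pair bears directly on this exchange, so the expectation rests only on where compound 1 stands and on the fact that the other compound carrying a methylsulfanyl group, compound 2, gives 0%. Because compound 1 gives 32% while the two compounds without the thiazolyl ring sit near zero, compound 4 is expected to show less inhibition in this assay, a step of a number 20 percentage points lower from compound 1 to compound 4 (beyond the scatter). The estimated value for compound 4 in this assay is 12%, within a range from 0% to 30%.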

Compound 4, a percentage reported as inhibition, at one concentration (the size of the read-out at that concentration, not a potency): 0%
Compound 4: middle estimate off by 12 percentage points, on the high side; the measured number falls inside the stated range.
By their numbers in this assay, from the lowest: compounds 2, 4 and 3 (each within the scatter of the next); then compound 1.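

In this assay, for the compounds shown here, the exchange of 1,3-thiazol-2-yl for methylsulfanyl on an aromatic carbon, meta to a large group, gives a number 32 percentage points lower from compound 1 to compound 4 (beyond the scatter), and this is the first comparison that isolates this position. Going by these compounds alone, the only earlier step, a number 1 percentage points higher from compound 2 to compound 3 (within the scatter), concerned a change elsewhere in the molecule, whereas this pair shows that, with the rest of compound 1 held the same, the number depends strongly on the group at this place and compound 4 retains no inhibition at the concentration tested. Nothing among the data shown explains why the number falls with this exchange.

Going by these compounds, what remains open is whether the five-membered aromatic ring with its hetero atoms matters as such or whether any ring at this place would keep the inhibition, a question that a phenyl, a 2-pyridyl or a 1,3-oxazol-2-yl group could address. On these data alone, it also remains open whether 1,3-thiazol-2-yl would give a similar number when combined with the amide portions of compound 2 or compound 3.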